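From cyclohexylamino to 3-methylpiperidin-1-yl: estimating compound 3

The compounds below may be only part of what the source reports. "The series", "measured", "known", "first", "only" and "open" are said of these compounds alone.

Compound 1 `CCNCC(=O)N1N=C(c2cc3ccccc3oc2=O)CC1c1ccccc1` and compound 2 `O=C(CNC1CCCCC1)N1N=C(c2cc3ccccc3oc2=O)CC1c1ccccc1` share a core and differ only in the group on an amine nitrogen. In a functional assay on MGC-803 cells (Homo sapiens) for cytotoxicity, read by MTT assay, with a stated time of 48 h (on this read-out lower numbers stand for stronger inhibition and higher numbers for weaker inhibition), compound 1 gives 26600 nM and compound 2 gives 26400 nM, so compound 2 stands level with compound 1 within the scatter. Compound 3 `CC1CCCN(CC(=O)N2N=C(c3cc4ccccc4oc3=O)CC2c2ccccc2)C1` is built from the same atoms, joined differently: 3-methylpiperidin-1-yl in place of cyclohexylamino on a saturated chain carbon bound to a carbonyl carbon. For the measured compounds named here, the only measured step that bears on this is cyclohexyl in place of ethyl on an amine nitrogen, a 1.0-fold lower number from compound 1 to compound 2 (0.00 log units; within the scatter), which is within the scatter. Neither measured compound carries a 3-methylpiperidin-1-yl group, so this evidence is thin. The expected change is none beyond the scatter in this assay, an estimated 1.1-fold lower number from compound 2 to compound 3 (0.02 log units; within the scatter). For compound 3 the estimated value is 25000 nM, with an expected range of 11000 nM to 55000 nM.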

Compound 3, half-maximal inhibitory concentration: "not active" (no number reported)
Compound 3: no number reported; no gap can be computed for the estimate.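

For the compounds shown here, compound 3 is recorded as "not active" in this assay with no number, so no step from compound 2 to compound 3 can be read. How far 3-methylpiperidin-1-yl in place of cyclohexylamino moves the number stays open, and no measurement shown explains this result.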